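The compounds below may be only part of what the source reports. "The series", "measured", "known", "first", "only" and "open" are said of these compounds alone.

Measured compounds:

Compound 1 `CC(=O)OCC(=O)[C@H](C[C@@H]1CCNC1=O)NC(=O)[C@H](CC(C)C)NC(=O)OCc1cccc(Cl)c1`: in a toxicity assay on A549 cells (Homo sapiens) for cytotoxicity, read by luminescence and CellTiter-Glo, with a stated time of 24 h (a lower number here means that less compound is tolerated, a higher number that more compound is tolerated), compound 1 gives only the assay limit > 200000 nM.
Compound 2 `COc1cccc2[nH]c(C(=O)N[C@@H](CC(C)C)C(=O)N[C@@H](C[C@@H]3CCCNC3=O)C(=O)CO)cc12`: in this assay compound 2 gives only the assay limit > 200000 nM.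
Compound 3 `COc1cccc2[nH]c(C(=O)N[C@@H](CC(C)C)C(=O)N[C@@H](C[C@@H]3CCCNC3=O)C(=O)COC(=O)C(C)(C)C(F)(F)F)cc12`: in this assay compound 3 gives only the assay limit > 200000 nM.

Compound 3 therefore stands at a limit, not at a number, and the other two values shown are limits as well. For the measured compounds named here, the single measured step, a step that the two limits leave unreadable from compound 2 to compound 3, cannot be read because the limit of > 200000 nM in this assay, at which 3 of the 3 values shown sit, holds both of its ends.

Compound 4 `COc1cccc2[nH]c(C(=O)N[C@@H](CC(C)C)C(=O)N[C@@H](C[C@@H]3CCCNC3=O)C(=O)COC(=O)C3(C(F)(F)F)CCCCC3)cc12` differs from compound 3 by a group of 10 heavy atoms (7 carbon, 3 fluorine; one six-membered non-aromatic ring of carbon only) in place of a group of 7 heavy atoms (4 carbon, 3 fluorine; no ring), on a carbonyl carbon.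

No readable measured step bears on this change, so no step beyond the scatter is expected; the expected step is a step that the limit leaves unreadable from compound 3 to compound 4. Compound 4 is estimated at 300000 nM, within 100000 nM to 1000000 nM, most likely reported again only as a limit.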

Compound 4, half-maximal cytotoxic concentration: > 200000 nM
Compound 4 gave a limit, no number (the forecaster's own chance of this, stated with the estimate: 85%); the middle value does not contradict the limit.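

For the compounds shown here, no step to compound 4 can be read from compound 2 or compound 3, because each step has both ends at one limit: the limit of > 200000 nM in this assay, at which 4 of the 4 values shown sit. In this assay the compounds shown leave open where any actual cytotoxic concentration lies.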